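Shifting the Hydroxyl: From Compound 2 to Compound 3

The source may report more compounds than this note shows. Statements on the series, on what has been measured and on what is new or still open speak of the compounds shown alone.

Compound 2 `Oc1ccc(-c2cc(-c3ccco3)cc(-c3ccccc3O)n2)cc1` was tested in a functional assay on HCT-15 cells (Homo sapiens) for cytotoxicity, read by CCK-8 assay; on this read-out lower numbers stand for stronger inhibition and higher numbers for weaker inhibition; there compound 2 gives > 50000 nM, which is a limit of the assay and not a number. Compound 1 `Oc1ccc(-c2cc(-c3ccsc3)cc(-c3ccccc3O)n2)cc1` carries thiophen-3-yl where compound 2 carries furan-2-yl. In this assay compound 1 gives > 50000 nM, again a limit. The step that the two limits leave unreadable from compound 1 to compound 2 therefore cannot be read, as the limit of > 50000 nM in this assay, at which 2 of the 2 values shown sit, shows. Compound 3 `Oc1ccc(-c2cc(-c3ccco3)cc(-c3ccc(O)cc3)n2)cc1` differs from compound 2 by 4-hydroxyphenyl in place of 2-hydroxyphenyl on an aromatic carbon. Within the data shown here, no measured step bears directly on this change, and both values known so far in this assay sit at the limit, so nothing points to a gain or a loss beyond the scatter. The expected step from compound 2 to compound 3 is accordingly a step that the limit leaves unreadable from compound 2 to compound 3. Compound 3 is estimated in this assay at 60000 nM, with a range from 15000 nM to 250000 nM, most likely again reported as a limit.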

Compound 3, half-maximal inhibitory concentration: 14000 nM
Estimate against measurement, compound 3: 4.3-fold (0.63 log units) above; measured number below the stated range.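

The change from 2-hydroxyphenyl to 4-hydroxyphenyl, on the carbon next to the ring nitrogen, gives an at least 3.5-fold lower number from compound 2 to compound 3 (0.55 log units; beyond the scatter) in this assay. The two groups hold the same atoms, so in this one pair the placing of the hydroxyl alone separates a limit from a measured number, and the size of the step is only a lower bound. The earlier step between compound 1 and compound 2 cannot be read, and compound 2 remains a limit and not a number: the limit of > 50000 nM in this assay, at which 2 of the 3 values shown sit.

The compounds shown leave open whether the same gain would appear with thiophen-3-yl in place of furan-2-yl. They also leave open how this position would respond to an unsubstituted phenyl, or to an amine or a carboxylic acid in place of the hydroxyl.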